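The source may hold more compounds than are shown below. What is called first, only, known or untested is meant among the compounds shown, and "the series" means these compounds.

Measured so far in a functional assay on the whole organism for inhibition, with Rattus norvegicus as the target, read by paw edema, with stated times of 30 min and 4 h, at a dose of 0.28 mmol/kg by the oral route; on this read-out higher numbers stand for more inhibition at the one dose given (going by the name of the read-out) and lower numbers for less inhibition:

compound 1 `COc1ccc(NC(=O)c2nc(-c3cc(OC)c(OC)c(OC)c3)n(-c3ccc(OC)cc3)n2)cc1` gives 63%
compound 2 `COc1ccc(-n2nc(C(=O)Nc3ccccc3OC)nc2-c2cc(OC)c(OC)c(OC)c2)cc1` gives 24%
compound 3 `COc1ccc(-n2nc(C(=O)Nc3cccc(F)c3)nc2-c2cc(OC)c(OC)c(OC)c2)cc1` gives 70%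

Compound 3 stands highest of the three numbers, though only by a number 7 percentage points higher from compound 1 to compound 3 (within the scatter), while a number 46 percentage points higher from compound 2 to compound 3 (beyond the scatter) is large. The next compound, compound 4 `COc1ccc(-n2nc(C(=O)Nc3ccccc3)nc2-c2cc(OC)c(OC)c(OC)c2)cc1`, differs from compound 3 by hydrogen in place of fluoro on an aromatic carbon. Among the measured compounds shown here, no measured step varies this fluoro alone; the three steps all exchange the whole ring on the amide-type nitrogen. Of these, a number 7 percentage points higher from compound 1 to compound 3 (within the scatter) shows that exchanging 4-methoxyphenyl for 3-fluorophenyl changes little, whereas a number 39 percentage points lower from compound 1 to compound 2 (beyond the scatter) and a number 46 percentage points higher from compound 2 to compound 3 (beyond the scatter) are large. Removing the fluoro is therefore expected to give no step beyond the scatter in this assay. Compound 4 is estimated at 62%, range 45% to 78%. The expected step is a number 8 percentage points lower from compound 3 to compound 4 (within the scatter).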

Compound 4, a percentage reported as inhibition, in the whole organism at one dose (the size of the read-out at that dose, not a potency): 50%
Compound 4: the middle estimate sits 12 percentage points above what was measured; the range from low to high includes it.
By their numbers in this assay, from the lowest: compound 2; then compound 4; then compounds 1 and 3 (each within the scatter of the next).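

Working from this assay, the fluoro now has a reading of its own: with 3-fluorophenyl changed to phenyl and nothing else altered, the number falls beyond the scatter (a number 20 percentage points lower from compound 3 to compound 4 (beyond the scatter)). Hydrogen in place of methoxy does not act in one direction, since the number rises when the methoxy leaves the 2-methoxyphenyl ring (a number 26 percentage points higher from compound 2 to compound 4 (beyond the scatter)) and falls when it leaves the 4-methoxyphenyl ring (a number 13 percentage points lower from compound 1 to compound 4 (beyond the scatter)). No supporting data explain these steps.

Open, from the compounds shown here alone, is whether chloro, an amine or a carboxylic acid on this aromatic carbon would match the fluoro. Also open, going by these compounds, is whether 2-fluorophenyl or 4-fluorophenyl would follow the methoxy rings.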